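A few compounds are considered here, and "the series" means these few. Any claim that something is new, unique, unknown or untested is made for them only; others in the source may bear on it.

Compound 1 `CC1(c2ccc(NC(c3ccncc3)c3nnnn3C(C)(C)C)cc2)NC(=O)c2ccccc2N1`: "not determined" (no result reported) in an ADME assay on Vero cells (Chlorocebus sabaeus) for cytotoxicity, read by MTT assay, with a stated time of 72 h; on this read-out higher numbers stand for lower toxicity in this test and lower numbers for higher toxicity in this test.
Compound 2 `CC1(c2ccc(NC(c3ccc(F)cc3)c3nnnn3C(C)(C)C)cc2)NC(=O)c2ccccc2N1`: "not determined" (no result reported) in this assay.
Compound 3 `CN1CCN(c2ccc(-c3cc(-c4ccc(C5NC(=O)c6ccccc6N5)cc4)nc(N)n3)cc2)CC1`: 8320 nM in this assay.

Compound 3, which has a different core from the other two, is the only one of the three with a numerical result in this assay. Compound 2 stands without a single number, and compound 1 is the one further entry that also lacks a single number, so there is no measured value from which the step to compound 4 could be computed.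

Compound 4 `CC1(c2ccc(NC(c3ccc(Cl)cc3)c3nnnn3C(C)(C)C)cc2)NC(=O)c2ccccc2N1` shares its core with compound 2 and differs from it in one place: chloro in place of fluoro on an aromatic carbon. Exchanges of one halogen for another on an aromatic carbon are small changes in this kind of cytotoxicity test. With no measured neighbour to anchor a step, the expectation rests on the general pattern that compounds of this size give readings in the same broad region as compound 3, and that the step from compound 2 to compound 4 would lie within the usual scatter, in no particular direction. Compound 4 is therefore expected to give about 10000 nM in this assay, estimated to fall between 3000 nM and 35000 nM.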

Compound 4, half-maximal cytotoxic concentration: > 400000 nM
Compound 4: no number, only a limit (the forecaster's own chance of this, stated with the estimate: 35%); middle value at least 40-fold (1.60 log units) from the limit.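

Compound 4 gives > 400000 nM in this assay, which is a limit and not a number. Within the data shown here, compound 2 has no single number, so no step between compound 2 and compound 4 can be read. Going by these compounds, what the change from 4-fluorophenyl to 4-chlorophenyl does to this reading stays open.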